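The source may hold more compounds than are shown below. What is called first, only, known or untested is meant among the compounds shown, and "the series" means these compounds.

Compound 1 `O=C(/C=C/c1cccc(OCc2ccccc2)c1)c1ccc([N+](=O)[O-])cc1` – 23300 nM
Compound 2 `O=C(/C=C/c1cccc(OCc2ccccc2)c1)c1ccc(Cl)cc1` – 21500 nM

In a functional assay on MDA-MB-231 cells (Homo sapiens) for cytotoxicity, read by MTT assay, with a stated time of 68 h (on this read-out lower numbers stand for stronger inhibition and higher numbers for weaker inhibition), compound 2 gives 21500 nM and compound 1 gives 23300 nM as its neighbour, so the two stand level within the usual scatter.

Compound 3 `O=C(/C=C/c1cccc(OCc2ccccc2)c1)c1ccc(Cl)c(Cl)c1Cl` has not been measured yet. It differs from compound 2 in one place 2,3,4-trichlorophenyl in place of 4-chlorophenyl on a carbonyl carbon and in words this is 2,3,4-trichlorophenyl in place of 4-chlorophenyl on a carbonyl carbon.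

For the measured compounds named here, only one measured step is available: a 1.1-fold lower number from compound 1 to compound 2 (0.03 log units; within the scatter) for chloro in place of nitro on an aromatic carbon. That step swaps one group and adds no further chlorine, so it bears only loosely on the new change. Going by the values given here, no measured compound shows what added chlorines do. Starting from compound 2 at 21500 nM as the anchor, no step beyond the scatter is expected in this assay and the range is kept wide. The expected step is a 1.2-fold lower number from compound 2 to compound 3 (0.08 log units; within the scatter) by this estimate. For compound 3 the estimated value is 18000 nM with 7000 nM to 40000 nM as the likely span.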

Compound 3, half-maximal inhibitory concentration: 2400 nM
Beside the measured number, compound 3's estimate is 7.5-fold (0.88 log units) above it; the whole stated range lies above it.
By their numbers in this assay, from the lowest: compound 3; then compounds 2 and 1 (each within the scatter of the next).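

In this assay, the aryl group on the carbonyl carbon proves able to move the number well beyond the scatter: 2,3,4-trichlorophenyl in place of 4-chlorophenyl gives a 9.0-fold lower number from compound 2 to compound 3 (0.95 log units; beyond the scatter), and the same group in place of 4-nitrophenyl gives a 9.7-fold lower number from compound 1 to compound 3 (0.99 log units; beyond the scatter). Compounds 1 and 2 stood level, so the swap between nitro and chloro gave no hint of this, and only the change to the 2,3,4-trichlorophenyl group reveals that the position responds at all. Nothing available explains why this change has so large an effect.

The compounds shown do not tell whether one of the added chlorines alone accounts for the step or whether all of them are needed, as none carries a phenyl group with a chlorine count between those of compound 2 and compound 3. Also open, on these data alone, is how the same position would respond to other groups on the phenyl ring, such as fluoro, methoxy, an amine or a carboxylic acid.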